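Tolerated Concentration in BCBL1 Cells for a Guanine-Core Series

The source may hold more compounds than are shown below. What is called first, only, known or untested is meant among the compounds shown, and "the series" means these compounds.

Measured compounds:
compound 1, `C=CCOc1nc(N)nc2c1ncn2/C=C1/CC1(CO)CO`: > 20000 nM
compound 2, `Nc1nc(NC2CCCCC2)c2ncn(/C=C3/CC3(CO)CO)c2n1`: > 20000 nM

In an ADME assay on BCBL1 cells (Homo sapiens) for cytotoxicity, with a stated time of 7 days (a lower number here means that less compound is tolerated, a higher number that more compound is tolerated), compound 1 gives > 20000 nM, which is a limit of the assay rather than a number. Compound 2 gives > 20000 nM in this assay, again a limit. The step from compound 1 to compound 2, a step that the two limits leave unreadable from compound 1 to compound 2, cannot be read because of the limit of > 20000 nM in this assay, at which 2 of the 2 values shown sit. For the measured compounds named here, compound 2 therefore stands at the limit of this assay, as does the only other value shown.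

Compound 3, `Nc1nc(SCc2ccccc2)c2ncn(/C=C3/CC3(CO)CO)c2n1`, differs from compound 2 in one place: benzylsulfanyl in place of cyclohexylamino on an aromatic carbon. Going by the values given here, no measured step involves a benzylsulfanyl group, so the only bearing evidence is that both measured compounds sit at the limit, with no readable change between them. The step from compound 2 to compound 3 is therefore expected to be a step that the limit leaves unreadable from compound 2 to compound 3, meaning no movement beyond the scatter that can be told from these data. For compound 3 the estimate is 25000 nM in this assay, with a range from 10000 nM to 60000 nM, and most likely the assay will again report only a limit.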

Compound 3, half-maximal cytotoxic concentration: > 20000 nM
Compound 3 gave a limit, no number; the forecaster's own chance of this, stated with the estimate: 75%; the middle value lies beyond the limit too.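

In this assay compound 3 gives > 20000 nM as a limit and not a number. For the compounds shown here, no step from compound 1 or compound 2 to compound 3 can be read, because all values share one limit: the limit of > 20000 nM in this assay, at which 3 of the 3 values shown sit.

The compounds shown leave open how far each of compound 1, compound 2 and compound 3 lies beyond that limit, and which group at this place on the shared core would give a readable number.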